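The compounds below may be only part of what the source reports. "The series", "measured", "known", "first", "only" and "open" are said of these compounds alone.

Among the compounds with values here, in an ADME assay on cells (Hepatocyte, Rattus norvegicus) for metabolic stability (on this read-out higher numbers stand for fast clearance and lower numbers for slow clearance), compound 1 `CNC(=O)c1sc(N2CC3CC2(CNC(=O)c2c[nH]c4ncccc24)C3)nc1C(F)(F)F` gives 33 uL/min, while compound 2 `CNC(=O)c1sc(N2CC3CC2(CNC(=O)c2c[nH]c4ncc(C)cc24)C3)nc1C(F)(F)F` gives 92 uL/min, the higher of the two numbers measured so far. Within the data shown here, the only recorded step, a 2.8-fold higher number from compound 1 to compound 2 (0.45 log units; beyond the scatter), came with methyl in place of hydrogen on an aromatic carbon. Compound 3 `CNC(=O)c1sc(N2CC3CC2(CNC(=O)c2c[nH]c4ncc(Cl)cc24)C3)nc1C(F)(F)F` differs from compound 2 by chloro in place of methyl on an aromatic carbon. Among the measured compounds shown here, no measured step swaps methyl for chloro, so that earlier step bears only loosely on this one, and a change staying within the scatter is expected, namely a 1.3-fold lower number from compound 2 to compound 3 (0.12 log units; within the scatter). Compound 3 is therefore estimated at 70 uL/min, within a range from 35 uL/min to 140 uL/min.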

Compound 3, intrinsic clearance in a liver preparation (reported as CLH), per the amount of preparation that the assay uses in the Hepatocyte assay: 120 uL/min
For compound 3 the middle estimate is 1.7-fold (0.23 log units) below the measured one; low and high end bracket the measured number.
By their numbers in the Hepatocyte assay, from the lowest: compound 1; then compounds 2 and 3 (each within the scatter of the next).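

In the Hepatocyte assay, swapping methyl for chloro at this position leaves clearance unresolved, with a 1.3-fold higher number from compound 2 to compound 3 (0.12 log units; within the scatter), while adding chloro where compound 1 carries hydrogen gives a 3.6-fold higher number from compound 1 to compound 3 (0.56 log units; beyond the scatter). So a second group, not methyl alone, stands beyond the scatter from hydrogen here. In a physicochemical assay for lipophilicity, at pH 7.4 (on this read-out higher numbers stand for higher lipophilicity and lower numbers for lower lipophilicity), however, compound 2 gives 3.5 and compound 3 gives 4, so the two groups differ on this measure even though clearance does not separate them.

Still open, from the compounds shown here alone, is whether a nitrile or a methoxy group at this position would bring clearance back towards that of compound 1.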